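Swapping the Amide Substituent on a Shared Core

A few compounds are considered here, and "the series" means these few. Any claim that something is new, unique, unknown or untested is made for them only; others in the source may bear on it.

Measured so far:
compound 1 `COc1ccc(/C=C/c2cc(OC)cc(OC)c2/C=C/C(=O)NC2CC2)cc1`, 3940 nM
compound 2 `COc1ccc(/C=C/c2cc(OC)cc(OC)c2/C=C/C(=O)N2CCCCC2C)cc1`, 4350 nM
compound 3 `CCCCCN(CCCCC)C(=O)/C=C/c1c(/C=C/c2ccc(OC)cc2)cc(OC)cc1OC`, 6130 nM

In a functional assay on MCF7 cells (Homo sapiens) for inhibition, read by MTT assay, with a stated time of 48 h (a lower number here means a stronger inhibitor, a higher number a weaker inhibitor), compound 2 stands second highest of the three numbers. Its nearest neighbour is compound 1, with a 1.1-fold higher number from compound 1 to compound 2 (0.04 log units; within the scatter); its furthest is compound 3, with a 1.4-fold higher number from compound 2 to compound 3 (0.15 log units; within the scatter). Compound 4 `COc1ccc(/C=C/c2cc(OC)cc(OC)c2/C=C/C(=O)N(CC(C)C)CC(C)C)cc1` differs from compound 2 by diisobutylamino in place of 2-methylpiperidin-1-yl on a carbonyl carbon. Within the data shown here, the steps that bear on this are the two earlier moves to an acyclic dialkylamino group, a 1.4-fold higher number from compound 2 to compound 3 (0.15 log units; within the scatter) and a 1.6-fold higher number from compound 1 to compound 3 (0.19 log units; within the scatter), both within the scatter. Compound 4 is therefore expected to show no step beyond the scatter, a 1.1-fold higher number from compound 2 to compound 4 (0.06 log units; within the scatter). The estimated value of compound 4 in this assay is 5000 nM, with a range from 2500 nM to 10000 nM.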

Compound 4, half-maximal inhibitory concentration: 2390 nM
Compound 4: middle estimate off by 2.1-fold (0.32 log units), on the high side, and the stated range ends above it.
By their numbers in this assay, from the lowest: compounds 4, 1, 2 and 3 (each within the scatter of the next, the first and the last beyond it).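

In this assay, this position now gives its first step beyond the scatter, a 2.6-fold lower number from compound 3 to compound 4 (0.41 log units; beyond the scatter), a modest one between two acyclic dialkylamino groups, diisobutylamino and dipentylamino. Replacing the other amide substituents leaves compound 4 within the scatter, a 1.8-fold lower number from compound 2 to compound 4 (0.26 log units; within the scatter) and a 1.6-fold lower number from compound 1 to compound 4 (0.22 log units; within the scatter), so an acyclic dialkylamino group on this carbonyl carbon does not by itself set the number apart. No measurement here accounts for the step from dipentylamino.

Open, from the compounds shown here alone, is whether a shorter chain such as diethylamino, or a ring carrying an added oxygen such as morpholin-4-yl, would stand beyond the scatter of compound 4.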